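Methoxy Added Beside a Pyrazinylmethoxy Group, Seen Twice

The source may hold more compounds than are shown below. What is called first, only, known or untested is meant among the compounds shown, and "the series" means these compounds.

Measured compounds:
Compound 1 `COc1cc(CNC(=O)/C=C/c2cccc(OCc3nc(C)c(C)nc3C)c2)ccc1O` gives 8090 nM
Compound 2 `COc1cc(CNC(=O)/C=C/c2ccc(OCc3nc(C)c(C)nc3C)cc2)ccc1OCc1nc(C)c(C)nc1C` gives 7770 nM
Compound 3 `COc1cc(/C=C/C(=O)NCc2ccc(OCc3nc(C)c(C)nc3C)c(OC)c2)ccc1OCc1nc(C)c(C)nc1C` gives 11100 nM

These three numbers come from a functional assay on SH-SY5Y cells (Homo sapiens) for cytotoxicity, read by MTT assay, with stated times of 24 h and 4 h (on this read-out higher numbers stand for an effect only at larger amounts of compound and lower numbers for an effect already at smaller amounts), and all lie within the usual scatter of one another. Compound 2 and compound 3 differ in one place only, (methoxy in place of hydrogen on an aromatic carbon), and that change gave a 1.4-fold higher number from compound 2 to compound 3 (0.15 log units; within the scatter). The unmeasured compound 4 `COc1cc(CNC(=O)/C=C/c2ccc(OC)c(OCc3nc(C)c(C)nc3C)c2)ccc1O` arises from compound 1 by the same kind of change, (methoxy in place of hydrogen on an aromatic carbon); the surroundings differ in that the entering group is para to a large group in compound 4 but meta to a large group in compound 3. The difference between the cores of compound 1 and compound 2 is not broken down here. Because the earlier step was a 1.4-fold higher number from compound 2 to compound 3 (0.15 log units; within the scatter), the step from compound 1 to compound 4 is also expected to be small, a 1.2-fold higher number from compound 1 to compound 4 (0.07 log units; within the scatter). Compound 4 is therefore estimated at 9500 nM, most likely between 4500 nM and 20000 nM.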

Compound 4, half-maximal effective concentration: 9250 nM
Compound 4: middle estimate off by 1.0-fold (0.01 log units), on the high side; measured number inside the range.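

In this assay, placing a methoxy group ortho to a (3,5,6-trimethylpyrazin-2-yl)methoxy group gives a 1.1-fold higher number from compound 1 to compound 4 (0.06 log units; within the scatter). Set beside the earlier case, the change carries across these two cores without a detectable difference: the same change on two cores in this assay, a 1.4-fold higher number (0.15 log units; within the scatter) from compound 2 to compound 3 and a 1.1-fold higher number (0.06 log units; within the scatter) from compound 1 to compound 4, 1.2-fold (0.10 log units) apart, within the scatter of two such steps. Going by these compounds alone, this shows only that the change gave a step within the scatter on both cores; it does not show that the same would hold on other cores or at other ring positions, and steps this small cannot separate a slight real effect from scatter.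

On these data alone, it remains open whether an amine or a carboxylic acid on that aromatic carbon would give a step beyond the scatter. The same question stands for a longer chain, such as ethoxy, in place of methoxy.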